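Phenoxy in Place of Phenyl: What to Expect for Compound 3

This account rests on a few compounds, and the source may have more. Where it says the series, first, only, none or still open, it means among the compounds named here.

Compound 1 `O=C(O)CCc1ccc(NCc2ccc(-c3ccccc3)cc2)cc1` was tested in a functional assay for agonist activity at Free fatty acid receptor 1 (Homo sapiens) (on this read-out higher numbers stand for an effect only at larger amounts of compound and lower numbers for an effect already at smaller amounts), where compound 1 gives 251 nM. Among the two compounds measured so far, compound 1 stands at the lowest number. Its companion, compound 2 `O=C(O)CCCc1ccc(NCc2ccc(-c3ccccc3)cc2)cc1`, carries carboxymethyl in place of carboxy on a saturated chain carbon, two bonds along the chain from an aromatic carbon; in this assay compound 2 gives 1580 nM, and the step of a 6.3-fold higher number from compound 1 to compound 2 (0.80 log units; beyond the scatter) lies beyond the scatter. Compound 3 `O=C(O)CCc1ccc(NCc2ccc(Oc3ccccc3)cc2)cc1` has not yet been measured. It differs from compound 1 in this way: phenoxy in place of phenyl on an aromatic carbon. For the measured compounds named here, the single measured step concerns the chain that carries the carboxy group, not the ring at the far end of the molecule where the change in compound 3 sits, so no measured step bears directly on this change. With nothing pointing either way, the step is expected to stay within the scatter, meaning a 1.3-fold higher number from compound 1 to compound 3 (0.11 log units; within the scatter). For compound 3 in this assay the estimate is 320 nM, with a range from 80 nM to 1300 nM.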

Compound 3, half-maximal effective concentration: 195 nM
Estimate against measurement, compound 3: 1.6-fold (0.22 log units) above, and the stated range covers the measured number.
By their numbers in this assay, from the lowest: compounds 3 and 1 (each within the scatter of the next); then compound 2.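

Replacing phenyl with phenoxy gives a 1.3-fold lower number from compound 1 to compound 3 (0.11 log units; within the scatter) in this assay, so this position, on an aromatic carbon para to a large group, accepts a group with 7 heavy atoms and 1 hydrogen-bond acceptor in place of one with 6 heavy atoms and no acceptor, and the two compounds cannot be told apart on this read-out. The earlier compounds shown here offered only a change in the chain that carries the acid, a 6.3-fold higher number from compound 1 to compound 2 (0.80 log units; beyond the scatter), which lies beyond the scatter, whereas this first change at the other end of the molecule stays within it, so the two places now differ in what the measured steps show, with one step read at each. No measurement is at hand that would explain the result for phenoxy at this position.

The compounds shown leave open whether a benzyloxy group, a phenylamino group or a methoxy group at the same place would also stay within the scatter of compound 1. They also leave open whether phenoxy would give a similar step when joined to the longer acid chain of compound 2, or when a fluorine or a chlorine is added to its outer ring.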